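Moving a trifluoromethyl group on a diaryl urea

The source may report more compounds than this note shows. Statements on the series, on what has been measured and on what is new or still open speak of the compounds shown alone.

Compound 2 `CN(C)CCCn1cnnc1-c1cc(Oc2ccc(NC(=O)Nc3cccc(C(F)(F)F)c3)cc2F)ccn1` gives 1790 nM in a functional assay on NCI-H460 cells (Homo sapiens) for antiproliferative activity, read by MTT assay, with a stated time of 72 h; a higher number here means a weaker inhibitor, a lower number a stronger inhibitor. This is the only numerical value among the two measurements shown; the other, for compound 1 `CN(C)CCn1cnnc1-c1cc(Oc2ccc(NC(=O)Nc3ccccc3C(F)(F)F)cc2F)ccn1`, is a limit of the assay rather than a number, at > 50000 nM. Compound 1 thus sits at the limit of > 50000 nM in this assay, at which 1 of the 2 values shown sits. Compound 3 `CN(C)CCCn1cnnc1-c1cc(Oc2ccc(NC(=O)Nc3ccccc3C(F)(F)F)cc2F)ccn1` has not yet been measured. It differs from compound 2 in one respect: 2-(trifluoromethyl)phenyl in place of 3-(trifluoromethyl)phenyl on an amide-type nitrogen. Going by the values given here, no step between two measured compounds that differ in only one place is available here, so the size of this change must be judged from what the two values show. Compound 3 shares its 2-(trifluoromethyl)phenyl group with compound 1, while compound 2 carries the 3-(trifluoromethyl)phenyl group. On that basis compound 3 is expected to be a weaker inhibitor than compound 2, by a step from compound 2 to compound 3 of an 8.4-fold higher number from compound 2 to compound 3 (0.92 log units; beyond the scatter), well beyond the usual scatter. In this assay compound 3 is estimated at 15000 nM, within a range from 4000 nM to 60000 nM, with a real chance that only a limit is reported.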

Compound 3, half-maximal inhibitory concentration: 10900 nM
Beside the measured number, compound 3's estimate is 1.4-fold (0.14 log units) above it; the measured number falls inside the stated range.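

In this assay, the trifluoromethyl move can now be read directly, with everything else in the molecule held the same: 2-(trifluoromethyl)phenyl in place of 3-(trifluoromethyl)phenyl on the amide-type nitrogen gives a 6.1-fold higher number from compound 2 to compound 3 (0.78 log units; beyond the scatter) for two compounds built from the same atoms, so where this one group sits matters here. Going by these compounds alone, the chain can also be read on its own for the first time, with the 2-(trifluoromethyl)phenyl group kept: (dimethylamino)methyl in place of dimethylamino on the saturated chain carbon gives an at least 4.5-fold lower number from compound 1 to compound 3 (0.66 log units; beyond the scatter) and so recovers measurable activity. The true size of that chain step stays unknown, since compound 1 is reported only as a limit of the assay: the limit of > 50000 nM in this assay, at which 1 of the 3 values shown sits.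

Within the data shown here, the chain step is seen only with the 2-(trifluoromethyl)phenyl group, so whether it keeps its size with the 3-(trifluoromethyl)phenyl group stays open. Also open, as far as these compounds go, is how a nitrile or a chlorine in place of the trifluoromethyl group, or a longer chain ending in a morpholine, would read in this assay on this shared core.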